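Replacing the Phenyl Group: From Compound 2 to Compound 4

The source may report more compounds than this note shows. Statements on the series, on what has been measured and on what is new or still open speak of the compounds shown alone.

Measured so far in a functional assay on Jurkat cells for inhibition of nuclear factor NF-kappa-B complex (Homo sapiens); a lower number here means a stronger inhibitor, a higher number a weaker inhibitor:
Compound 1 `CCOC(=O)c1cnc(C)nc1NN1C(=O)C=C(C)C1=O`, bearing a methyl group, gives 16000 nM.
Compound 2 `CCOC(=O)c1cnc(-c2ccccc2)nc1NN1C(=O)C=C(C)C1=O`, bearing a phenyl group, gives 100 nM.
Compound 3 `CCOC(=O)c1cnc(-c2ccc(C(F)(F)F)cc2)nc1NN1C(=O)C=C(C)C1=O`, bearing a 4-(trifluoromethyl)phenyl group, gives 400 nM.

Compound 2 holds the lowest number of the three in this assay: compound 3 is the nearest, with a 4.0-fold higher number from compound 2 to compound 3 (0.60 log units; beyond the scatter), and compound 1 lies at the far end, as seen in a 160-fold lower number from compound 1 to compound 2 (2.20 log units; beyond the scatter). Compound 4 `CCOC(=O)c1cnc(CC2=CCCCC2)nc1NN1C(=O)C=C(C)C1=O` differs from compound 2 in one place: (cyclohex-1-en-1-yl)methyl in place of phenyl on an aromatic carbon. Among the compounds with values here, no measured step exchanges phenyl for a non-aromatic group, so the earlier steps bear on it only indirectly. The steps of a 160-fold lower number from compound 1 to compound 2 (2.20 log units; beyond the scatter) and a 40-fold lower number from compound 1 to compound 3 (1.60 log units; beyond the scatter) show that a large gain came with the move from methyl to an aromatic ring on that carbon, while a 4.0-fold higher number from compound 2 to compound 3 (0.60 log units; beyond the scatter) shows that altering the ring itself moved the number only modestly. Compound 4 keeps a six-membered ring of carbon, but a non-aromatic one, so a weakening beyond the scatter is expected, though not back to the level of compound 1. Compound 4 is therefore estimated at 2000 nM, within 400 nM to 10000 nM, which means a 20-fold higher number from compound 2 to compound 4 (1.30 log units; beyond the scatter).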

Compound 4, half-maximal inhibitory concentration: 2000 nM
The estimate for compound 4 equals the measured number at the digits printed, and the stated range covers the measured number.
By their numbers in this assay, from the lowest: compound 2; then compound 3; then compound 4; then compound 1.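

In this assay, this position now has a group whose six-membered carbon ring is non-aromatic and sits on a one-carbon link, and it compares poorly with both aromatic groups: a 20-fold higher number from compound 2 to compound 4 (1.30 log units; beyond the scatter), and a 5.0-fold higher number from compound 3 to compound 4 (0.70 log units; beyond the scatter). Even so, part of the gain over methyl survives, with an 8.0-fold lower number from compound 1 to compound 4 (0.90 log units; beyond the scatter), so among these compounds a directly attached aromatic ring is not the only group at this position that gives a lower number than methyl. The data shown offer no measured explanation for these differences.

This change combines the loss of aromaticity with an added carbon link, and the compounds shown do not separate the two; a benzyl or a directly attached cyclohexyl group would do so. They also leave open how an amine or a pyridine ring would read at this position.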